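The compounds below may be only part of what the source reports. "The series", "measured", "known", "first", "only" and "open" are said of these compounds alone.

Of the compounds shown here, three have so far been measured in an ADME assay on a cell-free system (plasma, Homo sapiens) for metabolic stability; a higher number here means that the compound lasts longer, a lower number that the compound disappears faster. Compound 1 `Cc1cc(C)nc(N(COC(=O)c2ccccc2)S(=O)(=O)c2ccc(N)cc2)n1` gives 0.69 h, and compound 2 `NCCCC[C@H](N)C(=O)OC[C@H]1O[C@@H](n2cc(F)c(=O)[nH]c2=O)C[C@@H]1O` gives 0.647 h. Compound 3 `C[C@H](NC(=O)[C@H](N)CCC(=O)OCc1ccccc1)C(=O)O` stands highest of the three with 2.63 h, a gap above compound 1 and compound 2 that lies beyond the usual scatter. Compound 4 `C[C@H](NC(=O)[C@H](N)CCC(=O)OCc1ccc(F)cc1)C(=O)O` differs from compound 3 in a single place: fluoro in place of hydrogen on an aromatic carbon, so that the phenyl becomes a 4-fluorophenyl. For the measured compounds named here, no measured pair shows what this change does, so the expectation rests on compound 3 alone. In this assay the expected step is a 1.0-fold lower number from compound 3 to compound 4 (0.00 log units; within the scatter), a change within the scatter in either direction. The estimate for compound 4 is 2.6 h, with an expected range from 1.3 h to 5.2 h.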

Compound 4, half-life: 2 h
Estimate against measurement, compound 4: 1.3-fold (0.11 log units) above; the range from low to high includes it.
By their numbers in this assay, from the lowest: compounds 2 and 1 (each within the scatter of the next); then compounds 4 and 3 (each within the scatter of the next).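

In this assay this first pair differing in one place gives a 1.3-fold lower number from compound 3 to compound 4 (0.12 log units; within the scatter) when phenyl becomes 4-fluorophenyl. Fluoro on this aromatic carbon, para to a large group, therefore leaves the half-life indistinguishable from that with hydrogen. Nothing at hand explains this result. Going by these compounds, whether a chlorine, a methoxy group or a nitrile at the same carbon would also leave the half-life unchanged remains open. So does whether fluoro would read the same on the phenyl of compound 1.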